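The source may report more compounds than this note shows. Statements on the series, on what has been measured and on what is new or still open speak of the compounds shown alone.

Compound 1 `COc1ccc2nc(Nc3ccnc(Nc4ccc(S(N)(=O)=O)cc4)n3)sc2c1` is measured in a functional assay on PC-3 cells (Homo sapiens) for antiproliferative activity, read by MTT assay, with a stated time of 48 h (a higher number here means a weaker inhibitor, a lower number a stronger inhibitor), and gives 3030 nM. Among the two numbers recorded, compound 1 sits at the higher end, but its nearest neighbour, compound 2 `CS(=O)(=O)c1ccc(Nc2ncc(F)c(Nc3nc4ccccc4s3)n2)cc1`, gives 2830 nM in this assay, and the two values fall within the usual scatter of each other, so nothing separates them. Going by the values given here, compound 3 `Cc1cnc(Nc2ccc(S(N)(=O)=O)cc2)nc1Nc1nc2ccccc2s1` is reported in this assay only as a limit, > 50000 nM, and no number stands for it; this is the one value that sits at the limit of > 50000 nM in this assay, at which 1 of the 3 values shown sits.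

Compound 4 `Cc1ccc2nc(Nc3ccnc(Nc4ccc(S(N)(=O)=O)cc4)n3)sc2c1` has not yet been measured in this assay. It differs from compound 1 at a single site: methyl in place of methoxy on an aromatic carbon. The shared core of compound 1 is otherwise kept unchanged. Among the compounds with values here, no step between measured compounds of this kind is available, so the size of the change can only be expected, not read off.

The step from compound 1 to compound 4 is expected to be small, a 1.2-fold higher number from compound 1 to compound 4 (0.06 log units; within the scatter), and not clearly beyond the scatter in either direction. Compound 4 is therefore estimated at 3500 nM in this assay, with the value expected to fall between 1200 nM and 10000 nM.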

Compound 4, half-maximal inhibitory concentration: 1640 nM
Estimate against measurement, compound 4: 2.1-fold (0.33 log units) above; low and high end bracket the measured number.
By their numbers in this assay, from the lowest: compounds 4, 2 and 1 (each within the scatter of the next). At a limit, above all of these: compound 3.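

In this assay, methyl in place of methoxy on an aromatic carbon of the six-membered carbon ring, meta to a fused ring and para to a fused ring, gives a 1.8-fold lower number from compound 1 to compound 4 (0.27 log units; within the scatter). Going by these compounds alone, this is the first step between two measured compounds that differ in one place, and it shows that at this position the methoxy oxygen can be given up, leaving a single carbon in place of the two heavy atoms of methoxy, with no shift beyond the scatter of the assay. No measured property of either group bears on this step, so the data offer no account of it.

With methoxy and methyl as the only two groups shown at this position, it remains open whether the same flat response would hold for an amine, a carboxylic acid or a longer chain such as ethoxy, any of which could test the position more sharply than this pair does. Within the data shown here, it also remains open whether this step would keep its size on a different shared core, since the single pair gives no second example of the change to set beside it.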